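The source may report more compounds than this note shows. Statements on the series, on what has been measured and on what is new or still open speak of the compounds shown alone.

Measured compounds:
Compound 1, `O=C(CCCCCCCCn1cc(-c2cccnc2)nn1)Nc1ccccc1-c1ccccc1`: 35.6%
Compound 2, `O=C(CCCCCCCCn1cc(-c2cccnc2)nn1)Nc1ccccc1Cc1ccccc1`: 74.7%
Compound 3, `O=C(CCCCCCn1cc(-c2cccnc2)nn1)Nc1ccccc1Oc1ccccc1`: 81.3%

All three were tested in a functional assay on SH-SY5Y cells (Homo sapiens) for cytotoxicity, tested at 300 nM; on this read-out lower numbers stand for a stronger effect and higher numbers for a weaker effect at the one concentration tested. Compound 2 stands second highest of the three numbers; compound 3 is nearest, within the scatter of compound 2, while compound 1 lies furthest, well below it. Within the data shown here, the one step that changes the group on the aromatic carbon is a number 39.1 percentage points higher from compound 1 to compound 2 (beyond the scatter), a large step, showing that this position can move the read-out strongly. Compound 4, `O=C(CCCCCCCCn1cc(-c2cccnc2)nn1)Nc1ccccc1Oc1ccccc1`, is not yet measured; it differs from compound 2 as follows: phenoxy in place of benzyl on an aromatic carbon. Compound 3 also carries phenoxy on that aromatic carbon, though elsewhere it is not identical to compound 4, and in this assay compound 3 gives 81.3%, a number within the scatter of compound 2. Among the measured compounds shown here, no measured step covers the phenoxy for benzyl exchange directly. The step from compound 1 to compound 2 shows that a change at this carbon can be large, but the number of compound 3 gives no sign of movement. The expected step is therefore a number 3.3 percentage points higher from compound 2 to compound 4 (within the scatter), not beyond the scatter. Compound 4 is estimated at 78%, with a range from 60% to 95%.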

Compound 4, a percentage reported as activity, at one concentration (the size of the read-out at that concentration, not a potency): 79.5%
Compound 4: middle estimate off by 1.5 percentage points, on the low side; measured number inside the range.
By their numbers in this assay, from the lowest: compound 1; then compounds 2, 4 and 3 (each within the scatter of the next).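

With phenoxy now measured on this aromatic carbon, the exchange of benzyl for phenoxy in this assay gives a number 4.8 percentage points higher from compound 2 to compound 4 (within the scatter), so an added oxygen and hydrogen-bond acceptor in the group that enters does not separate the two at this position. Among these compounds, the exchange of phenyl for phenoxy gives a number 43.9 percentage points higher from compound 1 to compound 4 (beyond the scatter), a large step of the same kind as the one already seen with benzyl, and so among compounds 1, 2 and 4, which differ only at this carbon, phenyl is the one group that stands apart, with the two larger groups giving numbers within the scatter of each other. Nothing available here explains why phenyl stands apart from benzyl and phenoxy at this position.

The compounds shown leave open whether an anilino group or a benzyloxy group on this carbon would fall with benzyl and phenoxy or with phenyl. Among the compounds shown here, they also leave open whether the large step from phenyl would hold with a longer chain in place of the one carried by compounds 1, 2 and 4.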